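The source may hold more compounds than are shown below. What is called first, only, known or untested is meant among the compounds shown, and "the series" means these compounds.

Going by the values given here, in a functional assay (aorta) with Rattus norvegicus as the target (a higher number here means that more compound is needed for the effect, a lower number that less compound is needed), compound 3 `O=S1(=O)NC(NC2CC2)=Nc2ccc(Br)cc21` gives 89.4 uM, the higher of the two true numbers measured so far. Compound 1 `O=S1(=O)NC(NC2CC2)=Nc2ccc(F)cc21` gives > 300 uM, which is a limit of the assay and not a number. Compound 2 `C=CCNC1=Nc2ccc(Cl)cc2S(=O)(=O)N1` gives 28.9 uM, a lower number than that of compound 3.

Compound 4 `C=CCNC1=Nc2ccc(Br)cc2S(=O)(=O)N1` comes from compound 3 by a single change: allyl in place of cyclopropyl on an amine nitrogen. Among the compounds with values here, no measured step covers this change alone. Within the data shown here, the only measured step, an at least 3.3-fold lower number from compound 1 to compound 3 (0.52 log units; beyond the scatter), is bromo in place of fluoro, so it bears on the change only indirectly, by showing that compound 3 is the bromo member of its pair. The closest guide is compound 2 at 28.9 uM, which carries the allyl group but differs from compound 3 in more than that.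

A modest drop in this assay is therefore expected, an estimated 2.6-fold lower number from compound 3 to compound 4 (0.41 log units; beyond the scatter). For compound 4 the estimated value is 35 uM, with an expected range of 13 uM to 95 uM.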

Compound 4, concentration for half-maximal effect: 3 uM
Compound 4: middle estimate off by 12-fold (1.07 log units), on the high side; the whole stated range lies above it.
By their numbers in this assay, from the lowest: compound 4; then compound 2; then compound 3. At a limit, above all of these: compound 1.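

In this assay the amine nitrogen proves a sensitive place: with bromo held fixed, allyl in place of cyclopropyl gives a 30-fold lower number from compound 3 to compound 4 (1.47 log units; beyond the scatter), a large step. The earlier compounds shown here could not isolate this change, as compound 2 and compound 3 differ in both the amine group and the halogen. With allyl held fixed, going from the chloro to the bromo member gives a 9.6-fold lower number from compound 2 to compound 4 (0.98 log units; beyond the scatter), so the halogen also counts when the allyl group is present.

The compounds shown leave open whether the loss of the ring or the double bond of allyl carries the step, which a propyl group on the same nitrogen would separate, and whether a longer chain would lower the number further. Nothing measured here gives a property of either group that bears on these steps.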